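Compound 4: pyridin-3-yl in place of 4-methylphenyl

The source may hold more compounds than are shown below. What is called first, only, known or untested is meant among the compounds shown, and "the series" means these compounds.

In an ADME assay for permeability, using PAMPA, at pH 7.4 (on this read-out higher numbers stand for higher permeability and lower numbers for lower permeability), compound 2 (`Cc1ccc(NC(=O)Nc2cc(C)nc3ccccc23)cc1`) gives 669 10^-6 cm/s and compound 1 (`CSc1ccc(NC(=O)Nc2cc(C)nc3ccccc23)cc1`) gives 473 10^-6 cm/s so these two cannot be told apart (a 1.4-fold higher number from compound 1 to compound 2 (0.15 log units; within the scatter)). Compound 3 (`Cc1cc(NC(=O)Nc2ccc(SC(F)(F)F)cc2)c2ccccc2n1`) gives 206 10^-6 cm/s and lies lower than both. Compound 4 (`Cc1cc(NC(=O)Nc2cccnc2)c2ccccc2n1`) carries pyridin-3-yl in place of 4-methylphenyl on an amide-type nitrogen. Going by the values given here, no measured step exchanges the ring itself, so the evidence is indirect. Among the compounds with values here, the only steps beyond the scatter are downward and modest (a 2.3-fold lower number from compound 1 to compound 3 (0.36 log units; beyond the scatter)) and (a 3.2-fold lower number from compound 2 to compound 3 (0.51 log units; beyond the scatter)). A modest fall is therefore expected here, with low confidence (a 2.2-fold lower number from compound 2 to compound 4 (0.35 log units; beyond the scatter)). The estimate for compound 4 is 300 10^-6 cm/s (expected range 100 10^-6 cm/s to 700 10^-6 cm/s).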

Compound 4, apparent permeability: 63 10^-6 cm/s
Estimate against measurement, compound 4: 4.8-fold (0.68 log units) above; measured number below the stated range.
By their numbers in this assay, from the lowest: compound 4; then compound 3; then compounds 1 and 2 (each within the scatter of the next).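

In this assay, going by these compounds alone, pyridin-3-yl in place of 4-methylphenyl on the amide-type nitrogen gives an 11-fold lower number from compound 2 to compound 4 (1.03 log units; beyond the scatter), the only step printed as large. The earlier steps shown here changed only a group carried on the aromatic ring, whereas this one exchanges the ring itself and shows that the read-out responds strongly to that exchange. No measurement shown gives a cause for this fall. The compounds shown leave open whether the fall follows the ring nitrogen or the loss of the methyl. An unsubstituted phenyl and a methyl-bearing pyridinyl group would separate the two.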